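The source may report more compounds than this note shows. Statements on the series, on what has been measured and on what is new or still open speak of the compounds shown alone.

Compound 1, `CN(Cc1ccccc1)C(=O)C1CCN(C(=O)c2ccc(S(C)(=O)=O)c([N+](=O)[O-])c2)CC1`, gives in an assay on isolated protein for inhibition of thyroid hormone receptor beta (Homo sapiens), read by fluorescence polarization (a higher number here means a weaker inhibitor, a lower number a stronger inhibitor), only a limit, > 60000 nM.
Compound 2, `CN(Cc1ccccc1F)C(=O)C1CCN(C(=O)c2ccc(S(C)(=O)=O)c([N+](=O)[O-])c2)CC1`, gives in this assay only a limit, > 60000 nM.
Compound 3, `CN(CC(=O)N1CCN(c2ccc(F)cc2)CC1)C(=O)c1ccc(S(C)(=O)=O)c([N+](=O)[O-])c1`, gives in this assay only a limit, > 60000 nM.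

Compounds 1 and 2 share a core and differ by one change, (hydrogen in place of fluoro on an aromatic carbon). Because both values are limits, the step that the two limits leave unreadable from compound 2 to compound 1 cannot be read in size. Compound 3 carries a different core; the difference between the two cores is not broken down here. Compound 4, `CN(CC(=O)N1CCN(c2ccccc2)CC1)C(=O)c1ccc(S(C)(=O)=O)c([N+](=O)[O-])c1`, is not yet measured and differs from compound 3 by hydrogen in place of fluoro on an aromatic carbon. This is the same kind of change as that from compound 2 to compound 1, though the place differs: there the fluoro stood ortho to a large group, here it stands para to a large group. For compound 4 the step that the limit leaves unreadable from compound 3 to compound 4 is expected to remain unreadable, because every value shown sits at the limit of > 60000 nM in this assay, at which 3 of the 3 values shown sit, and nothing among compounds 1, 2 and 3 points to a measurable number. Compound 4 is therefore estimated at 100000 nM, most likely reported again as a limit.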

Compound 4, half-maximal inhibitory concentration: > 60000 nM
Compound 4 was reported as a limit; the forecaster's own chance of this, stated with the estimate: 85%; the middle value is on the limit's open side.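

The step from compound 3 to compound 4, 4-fluorophenyl to phenyl, cannot be read in size, since both compounds are reported only as limits in this assay: the limit of > 60000 nM in this assay, at which 4 of the 4 values shown sit.

The compounds shown leave open whether exchanging fluoro for hydrogen changes inhibition at all, and what structure would give a measurable value in this assay.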